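The source may hold more compounds than are shown below. What is called first, only, known or untested is meant among the compounds shown, and "the series" means these compounds.

Compound 1 `O=C1NCCN1CCCCCCN1CCC(c2cn(-c3ccc(F)cc3)c3ccc(Cl)cc23)CC1` is the starting point. In a functional assay on the whole organism for inhibition, with Rattus norvegicus as the target (on this read-out lower numbers stand for an effect already at smaller amounts and higher numbers for an effect only at larger amounts of compound), compound 1 gives > 2.2 umol/kg, which is a limit of the assay and not a number. Compound 1 thus sits at the limit of > 2.2 umol/kg in this assay, at which 1 of the 2 values shown sits. Compound 2 `CN1CC=C(c2cn(-c3ccc(F)cc3)c3ccc(F)cc23)CC1` gives 0.15 umol/kg in this assay. Compound 3 `CN1CCN(CCN2CCC(c3cn(-c4ccc(F)cc4)c4ccc(Cl)cc34)CC2)C1=O` differs from compound 1 in one place: 3-methyl-2-oxoimidazolidin-1-yl in place of 4-(2-oxoimidazolidin-1-yl)butyl on a saturated chain carbon, two bonds along the chain from an amine nitrogen in a ring. Going by the values given here, no measured pair shows this change, so its size is open; an expected move from the limit toward the range of compound 2 is an at least 7.3-fold lower number from compound 1 to compound 3 (0.86 log units; beyond the scatter). For compound 3 the estimated value in this assay is 0.3 umol/kg, between 0.08 umol/kg and 1.2 umol/kg.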

Compound 3, dose for half-maximal effect: 0.021 umol/kg
Estimate against measurement, compound 3: 14-fold (1.15 log units) above, and the stated range ends above it.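

This first measured pair at this position shows that the change matters a great deal in this assay: swapping 4-(2-oxoimidazolidin-1-yl)butyl for 3-methyl-2-oxoimidazolidin-1-yl gives an at least 100-fold lower number from compound 1 to compound 3 (2.02 log units; beyond the scatter). The true size of the step may be larger still, since compound 1 stands only at a limit: the limit of > 2.2 umol/kg in this assay, at which 1 of the 3 values shown sits.

The step removes the butyl chain and adds the methyl group together, so the compounds shown do not separate the two. As far as these compounds go, how an amine or a carboxylic acid would behave in place of 3-methyl-2-oxoimidazolidin-1-yl also remains open.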